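Notes on an antiproliferative series: the step to compound 3

The compounds below may be only part of what the source reports. "The series", "measured", "known", "first", "only" and "open" are said of these compounds alone.

Measured so far in a functional assay on HepG2 cells (Homo sapiens) for antiproliferative activity, read by MTT assay, with a stated time of 72 h; on this read-out lower numbers stand for stronger inhibition and higher numbers for weaker inhibition:
compound 1 `C[Si](C)(C)c1cn(C[C@H](O)[C@H]2OC(=O)C(OCc3ccccc3)=C2OCc2ccccc2)nn1` gives 24100 nM
compound 2 `O=C1O[C@H]([C@@H](O)Cn2cc(-c3cc(C(F)(F)F)cc(C(F)(F)F)c3)nn2)C(OCc2ccccc2)=C1OCc1ccccc1` gives 33800 nM

In this assay compound 1 has the smaller of the two numbers, but its gap to compound 2 lies within the usual scatter, so the two cannot be told apart on these data. Compound 3 `O=C1O[C@H]([C@@H](O)Cn2cc(CNS(=O)(=O)c3ccc(Cl)cc3)nn2)C(OCc2ccccc2)=C1OCc1ccccc1` is not yet measured. It differs from compound 1 by a group of 12 heavy atoms (7 carbon, 1 nitrogen, 2 oxygen, 1 sulfur, 1 chlorine; one six-membered aromatic ring of carbon only) in place of a group of 4 heavy atoms (3 carbon, 1 silicon; no ring), on an aromatic carbon. For the measured compounds named here, no step between measured compounds is available to size this change, and the one comparison in hand shows only two weak inhibitors that match each other. Compound 3 is therefore expected near 20000 nM (range 6000 nM to 60000 nM), with the step of a 1.2-fold lower number from compound 1 to compound 3 (0.08 log units; within the scatter) expected to stay within the scatter.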

Compound 3, half-maximal inhibitory concentration: 7510 nM
Beside the measured number, compound 3's estimate is 2.7-fold (0.43 log units) above it, and the stated range covers the measured number.
By their numbers in this assay, from the lowest: compound 3; then compounds 1 and 2 (each within the scatter of the next).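

At the aromatic carbon of the five-membered aromatic ring, the change of substituent moves the number in this assay: (((4-chlorophenyl)sulfonyl)amino)methyl in place of the group of 3 carbon and 1 silicon gives a 3.2-fold lower number from compound 1 to compound 3 (0.51 log units; beyond the scatter), so this position does respond, though the step is modest. No measurement bears on what lies behind this step.

The compounds shown leave open which part of the entering group matters, the 4-chlorophenyl ring, the sulfonyl or the amino link. A plain aminomethyl group or a carboxylic acid at this carbon would help separate these parts.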